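The compounds below may be only part of what the source reports. "The series", "measured", "known", "first", "only" and "open" are said of these compounds alone.

Measured in a functional assay on PC-3 cells (Homo sapiens) for cytotoxicity, read by MTT assay, with a stated time of 72 h; on this read-out lower numbers stand for stronger inhibition and higher numbers for weaker inhibition:
- compound 1 `O=S(=O)(c1ccccc1)c1nc2ccccc2nc1Nc1ccccc1`: 590 nM
- compound 2 `O=S(=O)(c1ccc(Br)cc1)c1nc2ccccc2nc1Nc1ccccc1`: 1180 nM

Going by the values given here, compound 2 stands at 1180 nM in this assay, and its value cannot be told apart from that of compound 1, since the only measured step is a 2.0-fold higher number from compound 1 to compound 2 (0.30 log units; within the scatter). Compound 3 `Nc1cccc(Nc2nc3ccccc3nc2S(=O)(=O)c2ccc(Br)cc2)c1` is the next to be measured. It differs from compound 2 by amino in place of hydrogen on an aromatic carbon, which is amino in place of hydrogen on an aromatic carbon. Among the compounds with values here, the one measured step involves bromo, not amino, so it bears only loosely on this change, and no measured pair tests amino directly. No step beyond the scatter is therefore expected, in either direction, though with wide uncertainty. The expected change is a 1.3-fold lower number from compound 2 to compound 3 (0.12 log units; within the scatter). For compound 3 the estimated value is 900 nM, with an expected range from 250 nM to 3200 nM.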

Compound 3, half-maximal inhibitory concentration: 9010 nM
Beside the measured number, compound 3's estimate is 10-fold (1.00 log units) below it; measured number above the stated range.
By their numbers in this assay, from the lowest: compounds 1 and 2 (each within the scatter of the next); then compound 3.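

Going from anilino to (3-aminophenyl)amino gives the only step beyond the scatter among these compounds in this assay (a 7.6-fold higher number from compound 2 to compound 3 (0.88 log units; beyond the scatter)), so this ring does not tolerate every change on an aromatic carbon, and amino meta to a large group goes with weaker inhibition. The earlier bromo change, by contrast, stayed within the scatter (a 2.0-fold higher number from compound 1 to compound 2 (0.30 log units; within the scatter)), so the compounds shown now include one change that moves the number clearly and one that does not. Nothing available gives a reason for the step.

Going by these compounds, it remains open whether amino would have the same effect on compound 1, which carries no bromo. On these data alone, it is also open whether a hydroxyl, methoxy or methyl group at this place, or amino elsewhere on the ring, would give a similar step.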